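Fluoro for hydroxy on the saturated carbon of compound 1

A few compounds are considered here, and "the series" means these few. Any claim that something is new, unique, unknown or untested is made for them only; others in the source may bear on it.

Compound 1 `CCS(=O)(=O)N(Cc1cccnc1)c1ccc(C(O)c2ccccc2)cc1` stands at the bottom of the measured range: in an assay on isolated protein with metabotropic glutamate receptor 2 (Homo sapiens) as the target (on this read-out higher numbers stand for an effect only at larger amounts of compound and lower numbers for an effect already at smaller amounts), compound 1 gives > 30000 nM, which is a limit of the assay rather than a number, namely (the limit of > 30000 nM in this assay, at which 1 of the 3 values shown sits). Compound 2 `CCS(=O)(=O)N(Cc1cccnc1)c1ccc(C(=O)c2ccccc2)cc1` gives 4200 nM in this assay. Compound 3 `CCS(=O)(=O)N(Cc1cccnc1)c1cccc(Cc2ccccc2)c1` gives 310 nM in this assay, and its value stands on its own beside the other two. Compound 4 `CCS(=O)(=O)N(Cc1cccnc1)c1ccc(C(F)c2ccccc2)cc1` differs from compound 1 by fluoro in place of hydroxy on a saturated chain carbon bound to two aromatic carbons. Within the data shown here, the only measured step that touches the same carbon is an at least 7.1-fold lower number from compound 1 to compound 2 (0.85 log units; beyond the scatter); it also replaces the hydroxy(phenyl)methyl group and thereby removes the hydroxy. Since compound 1 sits at a limit, that step has no fixed size, only a floor. The change to compound 4 removes the hydroxy as well but keeps the saturated carbon, so a lower number than that of compound 1 is expected in this assay, of uncertain size and likely smaller than the move to the carbonyl. For compound 4 the expected step is an at least 5.0-fold lower number from compound 1 to compound 4 (0.69 log units; beyond the scatter). For compound 4 in this assay the estimate is 6000 nM, with a range from 1500 nM to 30000 nM.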

Compound 4, half-maximal effective concentration: > 30000 nM
Compound 4: a limit, no number; the forecaster's own chance of this, stated with the estimate: 30%; middle value at least 5.0-fold (0.69 log units) from the limit.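

In this assay compound 4 gives > 30000 nM, which is a limit of the assay and not a number. The step between compound 1 and compound 4 cannot be read, so fluoro in place of hydroxy on this saturated chain carbon shows no measurable gain, and the series stays at the edge of the range: the limit of > 30000 nM in this assay, at which 2 of the 4 values shown sit. Fluoro(phenyl)methyl in place of benzoyl gives an at least 7.1-fold higher number from compound 2 to compound 4 (0.85 log units; beyond the scatter), so the lower number of the benzoyl compound does not follow from loss of the hydroxy alone, as the earlier step could not show when it changed the carbon as well.

From the compounds shown here alone, whether an amine or a methoxy group on the saturated chain carbon bound to two aromatic carbons would give a number in this assay stays open. Going by these compounds, how far compound 1 and compound 4 each lie past the limit also stays open, so no order between the two can be given.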